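The source may hold more compounds than are shown below. What is called first, only, known or untested is meant among the compounds shown, and "the series" means these compounds.

Measured so far:
compound 1, `COc1cccc(Cn2cc(-c3ccc(C)cc3)nn2)c1`: in a functional assay on B16 cells (Mus musculus) for cytotoxicity, read by MTT assay, with a stated time of 48 h (on this read-out lower numbers stand for stronger inhibition and higher numbers for weaker inhibition), compound 1 gives 19500 nM
compound 2, `CCOC(=O)Cn1cc(-c2ccc3ccccc3c2)nn1`: compound 2 gives only a limit, > 100000 nM
compound 3, `CC1(C)OC[C@H](Cn2cc(-c3ccc([N+](=O)[O-])cc3)nn2)O1`: compound 3 gives only a limit, > 100000 nM

Within the data shown here, of the three values in this assay, compound 1 is the only one with a number; compound 2 sits at a limit of the assay and not at a number, which is also (the limit of > 100000 nM in this assay, at which 2 of the 3 values shown sit). Nothing in the data places compound 2 against the others beyond that.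

The next compound is compound 4, `CC1(C)OCC(Cn2cc(-c3ccc4ccccc4c3)nn2)O1`. Its change from compound 2 is 2,2-dimethyl-1,3-dioxolan-4-yl in place of ethoxycarbonyl on a saturated chain carbon bound to an aromatic nitrogen. Among the measured compounds shown here, no measured pair in this assay differs in one place, so the size of this step has no direct precedent. Compound 3 also carries 2,2-dimethyl-1,3-dioxolan-4-yl and gives only a limit, > 100000 nM.

With the two nearest compounds both at the limit, compound 4 is expected to give no step beyond the scatter, a step that the limit leaves unreadable from compound 2 to compound 4, and most likely another limit. The estimate for compound 4 in this assay is 150000 nM, within 40000 nM to 600000 nM.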

Compound 4, half-maximal inhibitory concentration: 6600 nM
The estimate for compound 4 lay 23-fold (1.36 log units) above the measured number; the whole stated range lies above it.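

In this assay the place on a saturated chain carbon bound to an aromatic nitrogen proves able to move the read-out: 2,2-dimethyl-1,3-dioxolan-4-yl in place of ethoxycarbonyl gives an at least 15-fold lower number from compound 2 to compound 4 (1.18 log units; beyond the scatter). As far as these compounds go, the true size of this step stays unknown because compound 2 gives only a limit, not a number: the limit of > 100000 nM in this assay, at which 2 of the 4 values shown sit. The finding rests on this single pair, and compound 3, which also carries 2,2-dimethyl-1,3-dioxolan-4-yl, gives only a limit, > 100000 nM.

Open, from the compounds shown here alone, is whether the same exchange lowers the number on the other aryl groups of the series. Also open, going by these compounds, is how a carboxylic acid, a primary amine or a longer alkyl chain at this place would compare with 2,2-dimethyl-1,3-dioxolan-4-yl on the core of compound 4.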